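One Side Group Exchanged on a Shared Core

A few compounds are considered here, and "the series" means these few. Any claim that something is new, unique, unknown or untested is made for them only; others in the source may bear on it.

In a functional assay on SMMC-7721 cells (Homo sapiens) for antiproliferative activity, read by MTT assay, with a stated time of 48 h (on this read-out higher numbers stand for weaker inhibition and lower numbers for stronger inhibition), three compounds with the same core differ only in the group on a saturated chain carbon bound to a double-bonded ring carbon. Compound 1 `CC(C)=CCC[C@]1(C)/C=C/[C@@H](OC(=O)C=C(C)C)[C@](C)(O)/C=C/C(=O)/C(CCl)=C\C1`, with chloro, gives 840 nM. Compound 2 `CC(C)=CCC[C@]1(C)/C=C/[C@@H](OC(=O)C=C(C)C)[C@](C)(O)/C=C/C(=O)/C(CN2CCCC2)=C\C1`, with pyrrolidin-1-yl, gives 140 nM. Compound 3 `CC(C)=CCC[C@]1(C)/C=C/[C@@H](OC(=O)C=C(C)C)[C@](C)(O)/C=C/C(=O)/C(CN2CCN(C)CC2)=C\C1`, with 4-methylpiperazin-1-yl, gives 2940 nM, the highest number of the three and so the weakest inhibition.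

Compound 4 `CC(C)=CCC[C@]1(C)/C=C/[C@@H](OC(=O)C=C(C)C)[C@](C)(O)/C=C/C(=O)/C(Cn2cc(CO)nn2)=C\C1` is still unmeasured. It keeps the core but replaces the group of compound 3 with 4-(hydroxymethyl)-1H-1,2,3-triazol-1-yl: 4-(hydroxymethyl)-1H-1,2,3-triazol-1-yl in place of 4-methylpiperazin-1-yl on a saturated chain carbon bound to a double-bonded ring carbon.

All three measured steps change this same place, and all lie beyond the scatter: a 6.0-fold lower number from compound 1 to compound 2 (0.78 log units; beyond the scatter), a 3.5-fold higher number from compound 1 to compound 3 (0.54 log units; beyond the scatter) and a 21-fold higher number from compound 2 to compound 3 (1.32 log units; beyond the scatter). The number clearly responds to the group here, with steps ranging from modest to large. Going by the values given here, none of the measured compounds carries a triazole, however, so these steps give only a rough guide to size and direction. With compound 3 at 2940 nM, the top of the measured range, a modest fall seems likelier than a further rise.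

In this assay, the expected change is a 2.3-fold lower number from compound 3 to compound 4 (0.35 log units; beyond the scatter), and it may not clear the scatter. Compound 4 is estimated at 1300 nM, with an expected range of 300 nM to 5500 nM.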

Compound 4, half-maximal inhibitory concentration: 3560 nM
For compound 4 the middle estimate is 2.7-fold (0.44 log units) below the measured one, and the stated range covers the measured number.
By their numbers in this assay, from the lowest: compound 2; then compound 1; then compounds 3 and 4 (each within the scatter of the next).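

In this assay, the change gives a 1.2-fold higher number from compound 3 to compound 4 (0.08 log units; within the scatter), so two quite different groups cannot be told apart here, although they have the same heavy-atom count: one is a six-membered non-aromatic ring and the other a five-membered aromatic ring carrying a hydroxymethyl group. The result also shows that the large gap to pyrrolidin-1-yl is not unique to 4-methylpiperazin-1-yl, with a 25-fold higher number from compound 2 to compound 4 (1.41 log units; beyond the scatter), while the change from chloro gives a 4.2-fold higher number from compound 1 to compound 4 (0.63 log units; beyond the scatter), leaving compound 2 as the strongest inhibitor of the four. No measurement presented here explains why these two groups read alike or why pyrrolidin-1-yl stands apart.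

From the compounds shown here alone, it remains open whether the low number of compound 2 belongs to pyrrolidin-1-yl alone or would also appear with a piperidin-1-yl ring, a morpholin-4-yl ring or an open-chain diethylamino group on the same carbon. The compounds shown also cannot tell whether the hydroxymethyl group matters to the triazole's result, a question that a triazole bearing a plain methyl or phenyl group in its place could address.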